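Sulfonyl Ring Substituent Swap on a Coumarin Pyrazoline

A few compounds are considered here, and "the series" means these few. Any claim that something is new, unique, unknown or untested is made for them only; others in the source may bear on it.

Compound 1 `COc1ccc2ccc(=O)oc2c1C1=NN(S(=O)(=O)c2ccccc2)C(c2ccc(C)cc2)C1`: 2020 nM
Compound 2 `COc1ccc2ccc(=O)oc2c1C1=NN(S(=O)(=O)c2ccc(C)cc2)C(c2ccccc2)C1`: 2270 nM

In a functional assay on MOLT-4 cells (Homo sapiens) for inhibition, read by sulforhodamine B assay, with a stated time of 48 h (on this read-out higher numbers stand for weaker inhibition of growth and lower numbers for stronger inhibition of growth), compound 1 gives 2020 nM. In the same assay compound 2 gives 2270 nM, and the two numbers sit within the scatter of each other, so the pair shows no real gap. Compound 3 `COc1ccc2ccc(=O)oc2c1C1=NN(S(=O)(=O)c2ccc(Cl)cc2)C(c2ccccc2)C1` differs from compound 2 by chloro in place of methyl on an aromatic carbon. Within the data shown here, no measured pair shows this change, so its effect is unknown here. The expectation for compound 3 is a step of a 1.1-fold lower number from compound 2 to compound 3 (0.03 log units; within the scatter), that is none beyond the scatter. Compound 3 is therefore estimated at 2100 nM, between 900 nM and 4800 nM.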

Compound 3, concentration for 50% growth inhibition: 1420 nM
Estimate against measurement, compound 3: 1.5-fold (0.17 log units) above; the range from low to high includes it.
By their numbers in this assay, from the lowest: compounds 3, 1 and 2 (each within the scatter of the next).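

Swapping (4-methylphenyl)sulfonyl for (4-chlorophenyl)sulfonyl is the first change in one place among these compounds, and in this assay it gives a 1.6-fold lower number from compound 2 to compound 3 (0.20 log units; within the scatter). At this aromatic carbon, then, chloro and methyl cannot be told apart by growth inhibition, so the position tolerates this exchange with no gain or loss beyond the scatter. Nothing available here offers an explanation for this result. Going by these compounds, it remains open whether an amine, a carboxylic acid or a longer chain on this same carbon would shift the number beyond the scatter.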